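The compounds below may be only part of what the source reports. "The series", "measured", "known", "first", "only" and "open" are said of these compounds alone.

Working notes on the series. Compound 3 `Cc1ccccc1-n1cc(-c2ccc(NS(=O)(=O)c3c[nH]c(=O)[nH]c3=O)cc2)nn1` gives 3130 nM in a functional assay on A549 cells (Homo sapiens) for antiproliferative activity, read by MTT assay, with a stated time of 24 h (on this read-out lower numbers stand for stronger inhibition and higher numbers for weaker inhibition), and holds the lowest of the two numbers shown. Compound 1 `Cc1ccccc1-n1cc(-c2cccc(NS(=O)(=O)c3c[nH]c(=O)[nH]c3=O)c2)nn1` gives 5470 nM in this assay; the gap between compound 3 and compound 1 stays within the scatter, so no order between them is read. Compound 2 `O=c1[nH]cc(S(=O)(=O)Nc2cccc(-c3cn(-c4ccccc4F)nn3)c2)c(=O)[nH]1` reaches only a limit in this assay, namely > 20000 nM. One line marks this: the limit of > 20000 nM in this assay, at which 1 of the 3 values shown sits. Among the measured compounds shown here, the single measured step, an at least 3.6-fold higher number from compound 1 to compound 2 (0.56 log units; beyond the scatter), exchanges the group on the phenyl that sits on the aromatic nitrogen and goes toward weaker inhibition. Compound 4 `O=c1[nH]cc(S(=O)(=O)Nc2ccc(-c3cn(-c4ccc(Cl)cc4)nn3)cc2)c(=O)[nH]1` differs from compound 3 by 4-chlorophenyl in place of 2-methylphenyl on an aromatic nitrogen. The step from compound 1 to compound 2 bears on this change because an at least 3.6-fold higher number from compound 1 to compound 2 (0.56 log units; beyond the scatter) also alters the group on that same phenyl, and it was at least modest. A step of similar direction, of uncertain size, is therefore expected here, a 2.1-fold higher number from compound 3 to compound 4 (0.32 log units; beyond the scatter). For compound 4 the estimated value in this assay is 6500 nM, with a range from 2500 nM to 18000 nM.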

Compound 4, half-maximal inhibitory concentration: 1210 nM
Beside the measured number, compound 4's estimate is 5.4-fold (0.73 log units) above it; the measured number lies below the stated range.
By their numbers in this assay, from the lowest: compound 4; then compounds 3 and 1 (each within the scatter of the next). At a limit, above all of these: compound 2.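

In this assay, 4-chlorophenyl in place of 2-methylphenyl on the aromatic nitrogen gives a 2.6-fold lower number from compound 3 to compound 4 (0.41 log units; beyond the scatter), so a change of the phenyl at this position can also go toward stronger inhibition. The earlier step on this phenyl, an at least 3.6-fold higher number from compound 1 to compound 2 (0.56 log units; beyond the scatter), ran the other way, with a different entering group on a different parent, so the direction of one exchange here does not carry over to another. No measurement shown gives a cause for the step from compound 3 to compound 4.

Still open, as far as these compounds go, is whether this gain belongs to the chlorine, to its place on the phenyl or to the loss of the methyl, since the exchange alters all three at once. From the compounds shown here alone, how an amine or a carboxylic acid on this phenyl would read in this assay also remains open.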